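Trifluoromethyl hydrate amides: pyridin-4-yl replacing 3-bromophenyl

The source may report more compounds than this note shows. Statements on the series, on what has been measured and on what is new or still open speak of the compounds shown alone.

Measured so far:
compound 1 `O=C(CCCCCCNC(=O)C(O)(O)C(F)(F)F)Nc1cccc(Br)c1`, 3060 nM
compound 3 `O=C(CCCCCCCNC(=O)C(O)(O)C(F)(F)F)Nc1ccccc1`, 41700 nM
compound 2 `NC(=O)C(=O)NCCCCCC(=O)Nc1ccccc1`; compound 2 reaches only a limit of the assay, > 100000 nM.

In a functional assay on HCT-116 cells (Homo sapiens) for inhibition, read by colorimetric assay, with a stated time of 3 days (a higher number here means a weaker inhibitor, a lower number a stronger inhibitor), compound 1 gives 3060 nM, the lowest of the two numbers available. Within the data shown here, compound 3 gives 41700 nM, a gap to compound 1 that lies beyond the scatter, though the two differ in more than one place and no single step between them is resolved. Of the three values shown, one sits at the limit of > 100000 nM in this assay, at which 1 of the 3 values shown sits; that is the value of compound 2, and it is a limit rather than a number.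

Compound 4 `O=C(CCCCCCNC(=O)C(O)(O)C(F)(F)F)Nc1ccncc1` is not yet measured. It differs from compound 1 in one place: pyridin-4-yl in place of 3-bromophenyl on an amide-type nitrogen. The chain, the hydrate amide and the anilide carbonyl are kept. With no measured step of this kind in the series, the expectation rests on compound 1 alone. The step expected is a 4.9-fold higher number from compound 1 to compound 4 (0.69 log units; beyond the scatter), towards a weaker inhibitor, and probably beyond the scatter. Compound 4 is therefore expected at 15000 nM, within 4000 nM to 60000 nM.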

Compound 4, half-maximal inhibitory concentration: 6670 nM
Estimate against measurement, compound 4: 2.2-fold (0.35 log units) above, within the range that was stated.
By their numbers in this assay, from the lowest: compound 1; then compound 4; then compound 3. At a limit, above all of these: compound 2.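

In this assay, among these compounds, pyridin-4-yl in place of 3-bromophenyl on the amide-type nitrogen gives a 2.2-fold higher number from compound 1 to compound 4 (0.34 log units; beyond the scatter), the first single-place step. This step is modest, so at this position the bromine and the all-carbon ring are not needed for a measurable number, and a ring with one hetero atom is accepted with the chain and hydrate amide kept. Nothing measured here bears on why the number moves with this change.

The step changes two things at once, the bromine leaving and the ring nitrogen entering, and a plain phenyl on this same chain would be needed to separate them. From the compounds shown here alone, how an amine or a carboxylic acid on the ring would read at this position also remains open.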